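Ester series: half-life after swapping the amidine-type substituent

This account rests on a few compounds, and the source may have more. Where it says the series, first, only, none or still open, it means among the compounds named here.

Measured in an ADME assay on the whole organism (strain Sprague-Dawley) for metabolic stability, with Rattus norvegicus as the target, read by LC-MS, at a dose of 50 mg/kg by the oral route; on this read-out lower numbers stand for a shorter-lived compound and higher numbers for a longer-lived compound:
- compound 1 `CCC(CC)O[C@@H]1C=C(C(=O)O)C[C@H](NC(C)=N)[C@H]1NC(C)=O`: 1.13 h
- compound 2 `CCOC(=O)C1=C[C@@H](OC(CC)CC)[C@H](NC(C)=O)[C@@H](N/C(C)=N/O)C1`: 1.85 h

Of the compounds shown here, two have numbers in this assay so far. Among the compounds with values here, compound 2 stands at 1.85 h; compound 1 at 1.13 h lies within the usual scatter of that, so the two are not separated, and no step between them can be read. Compound 1 and compound 2 also differ in more than one place, so nothing is attributed to any single change.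

Within the data shown here, the next compound, compound 3 `CCOC(=O)C1=C[C@@H](OC(CC)CC)[C@H](NC(C)=O)[C@@H](NC(=N)N)C1`, keeps the ethyl ester and the rest of the core of compound 2 and changes only one group: a group of 3 heavy atoms (1 carbon, 2 nitrogen; no ring) in place of a group of 4 heavy atoms (2 carbon, 1 nitrogen, 1 oxygen; no ring), on an amine nitrogen. The entering group carries more hydrogen-bond donors and fewer acceptors than the group it replaces, and the oxygen leaves.

Among the measured compounds shown here, no measured pair isolates a change of this kind, so the expectation rests on compound 2 alone. The step of a 1.2-fold lower number from compound 2 to compound 3 (0.09 log units; within the scatter) is expected to be small, within the scatter, in either direction. Compound 3 is therefore expected to give about 1.5 h, with a range from 0.7 h to 3.2 h, because compound 2 gives 1.85 h and compound 1 gives 1.13 h.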

Compound 3, half-life: 1.45 h
Beside the measured number, compound 3's estimate is 1.0-fold (0.01 log units) above it; the measured number falls inside the stated range.
By their numbers in this assay, from the lowest: compounds 1, 3 and 2 (each within the scatter of the next).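

Within the data shown here, this is the first pair that differs in one place: on an amine nitrogen whose other neighbours are a saturated ring carbon, a group of 3 heavy atoms (1 carbon, 2 nitrogen; no ring) stands in place of a group of 4 heavy atoms (2 carbon, 1 nitrogen, 1 oxygen; no ring). In this assay this exchange gives a 1.3-fold lower number from compound 2 to compound 3 (0.11 log units; within the scatter), so the half-life does not separate the two groups on the ethyl ester core, even though the entering group carries more hydrogen-bond donors and fewer acceptors and the oxygen leaves. Nothing available bears on the reason for this result.

From the compounds shown here alone, whether a plain amine or a longer chain on that nitrogen would move the half-life beyond the usual scatter remains open. Going by these compounds, the part played by the ethyl ester also remains open, since compound 1 differs from the ester compounds in more than one place and no single change can be read from it.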